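Methyl for fluoro ortho to the oxadiazole on compound 2

The source may report more compounds than this note shows. Statements on the series, on what has been measured and on what is new or still open speak of the compounds shown alone.

Measured so far, in an assay on isolated protein for inhibition of tyrosine-protein kinase Mer (Homo sapiens), read by LC-MS; a lower number here means a stronger inhibitor, a higher number a weaker inhibitor:
- compound 1 `Cc1noc(C)c1-c1ccc(-c2nnc(N(C)Cc3ccc4nccn4c3)o2)cc1` gives 200 nM
- compound 2 `Cc1nn(C)c(C)c1-c1ccc(-c2nnc(N(C)Cc3ccc4nccn4c3)o2)c(F)c1` gives 12.6 nM

Compound 2 holds the lowest of the two numbers; compound 1 stands a good deal higher, a gap beyond the scatter, though the two differ in more than one place, so no single step can be read from them. Compound 3 `Cc1cc(-c2c(C)nn(C)c2C)ccc1-c1nnc(N(C)Cc2ccc3nccn3c2)o1` carries methyl in place of fluoro on an aromatic carbon, a methyl in place of fluoro on an aromatic carbon, ortho to a large group. Among the measured compounds shown here, no measured pair shows this swap, so the step is expected to be small and within the scatter, with any change more likely toward a higher number. For compound 3 the estimate is 20 nM, range 6 nM to 60 nM, a step of a 1.6-fold higher number from compound 2 to compound 3 (0.20 log units; within the scatter) expected from compound 2.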

Compound 3, half-maximal inhibitory concentration: 3.16 nM
Beside the measured number, compound 3's estimate is 6.3-fold (0.80 log units) above it; the whole stated range lies above it.
By their numbers in this assay, from the lowest: compound 3; then compound 2; then compound 1.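

Methyl in place of fluoro on this aromatic carbon, ortho to a large group, gives a 4.0-fold lower number from compound 2 to compound 3 (0.60 log units; beyond the scatter) in this assay, the first step in the series that can be read at a single place. This position therefore responds to an exchange of one heavy atom for another, with methyl ahead of fluoro. Nothing measured here explains the step. Still open, on these data alone, is how chloro, methoxy or nitrile would compare at this carbon. Also open, as far as these compounds go, is whether methyl gives a similar step with other groups in place of the 1,3,5-trimethyl-1H-pyrazol-4-yl group.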